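Swapping fluoro for chloro across two related cores

The compounds below may be only part of what the source reports. "The series", "measured", "known", "first", "only" and "open" are said of these compounds alone.

Compound 1 `N=C(N)Nc1cccc(C(=O)NNC(=O)CC(CC(=O)O)c2ccc(F)cc2)c1` and compound 2 `N=C(N)Nc1cccc(C(=O)NNC(=O)CC(CC(=O)O)c2ccc(Cl)cc2)c1` share a core and differ in one place: chloro in place of fluoro on an aromatic carbon. In a physicochemical assay for lipophilicity (a lower number here means a more polar compound, a higher number a more lipophilic compound), compound 1 gives 1.28, and compound 2 gives 1.68, so the step is a number 0.40 log units higher from compound 1 to compound 2 (beyond the scatter).

Compound 3 `N=C(N)Nc1cccc(C(=O)NNC(=O)NC(CC(=O)O)c2ccc(F)cc2)c1` has a different core; the difference between the two cores is not broken down here. In this assay compound 3 gives 0.86, the lowest of the three numbers, sitting beyond the scatter from both compound 1 and compound 2.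

Compound 4 `N=C(N)Nc1cccc(C(=O)NNC(=O)NC(CC(=O)O)c2ccc(Cl)cc2)c1` is not yet measured. It differs from compound 3 in exactly the same way that compound 2 differs from compound 1: chloro in place of fluoro on an aromatic carbon. The place of the change reads the same in both pairs, so this is the same change on a second core.

The expectation for compound 4 rests on that repeat: the step from compound 3 to compound 4 is expected to be a number 0.40 log units higher from compound 3 to compound 4 (beyond the scatter), because the measured step is a number 0.40 log units higher from compound 1 to compound 2 (beyond the scatter) and no other change is made. Compound 4 is therefore estimated at 1.26, with a likely range from 1 to 1.55.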

Compound 4, partition coefficient: 1.26
Beside the measured number, compound 4's estimate shows no gap at the digits printed, and the stated range covers the measured number.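

In this assay the change from 4-fluorophenyl to 4-chlorophenyl gives a number 0.40 log units higher from compound 3 to compound 4 (beyond the scatter) and the same change on the other core gives a number 0.40 log units higher from compound 1 to compound 2 (beyond the scatter) so the step has the same size on both cores. This shows that, for these four compounds, the step measured on one core carried over to the second core. It does not show that the step would hold on a third core, or that any other swap of groups would carry over in the same way, and nothing given here explains why the two steps match.

Still open, from the compounds shown here alone, is how the number moves when a bromo or a methoxy group takes the same place on each of the two cores, and whether those two steps would also match. Equally open, going by these compounds, is whether the step from fluoro to chloro would hold on a core with a methyl ester in place of the carboxylic acid.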